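A Difluorophenyl Swap Starting From the Assay Limit

The source may report more compounds than this note shows. Statements on the series, on what has been measured and on what is new or still open speak of the compounds shown alone.

Compound 1 (`CC(C)[C@H](NC(=O)COc1cccc2ccccc12)C(=O)N[C@@H](CC(=O)O)C(=O)COc1ccc(C(F)(F)F)cc1`) gives > 100000 nM in a functional assay on Jurkat cells (Homo sapiens) (on this read-out lower numbers stand for stronger inhibition and higher numbers for weaker inhibition), as a limit of the assay and not a number. Compound 2 (`CC(C)[C@H](NC(=O)COc1cccc2ccccc12)C(=O)N[C@@H](CC(=O)O)C(=O)COc1ccccc1F`) gives > 100000 nM in this assay as a limit too. Compound 2 therefore stands at the limit of > 100000 nM in this assay, at which 2 of the 2 values shown sit, and has no measured number. Compound 3 (`CC(C)[C@H](NC(=O)COc1cccc2ccccc12)C(=O)N[C@@H](CC(=O)O)C(=O)COc1ccc(F)c(F)c1`) differs from compound 2 by 3,4-difluorophenyl in place of 2-fluorophenyl on an oxygen on a saturated carbon and carries 3,4-difluorophenyl in place of 2-fluorophenyl on an oxygen on a saturated carbon. Among the compounds with values here, the only measured step bearing on this change is a step that the two limits leave unreadable from compound 1 to compound 2 and it offers no size to carry forward. No movement beyond the scatter is therefore expected in this assay and a further limit is the likeliest report. The expected change is a number no higher from compound 2 to compound 3 (the limit leaves the size open) in size. For compound 3 the estimate is 100000 nM with an expected range from 30000 nM to 300000 nM as its bounds.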

Compound 3, half-maximal inhibitory concentration: > 100000 nM
Compound 3 ended at the assay's limit; the forecaster's own chance of this, stated with the estimate: 80%; the middle value lies on the limit itself.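

Compound 1, compound 2 and compound 3 yield no readable step, as each gives a limit of the assay and not a number: the limit of > 100000 nM in this assay, at which 3 of the 3 values shown sit. The compounds shown leave open whether 4-(trifluoromethyl)phenyl, 2-fluorophenyl and 3,4-difluorophenyl differ at all in this assay.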